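The compounds below may be only part of what the source reports. "The series", "measured", "known", "first", "only" and "open" are said of these compounds alone.

Compound 1, `O=C1CSC(c2cccc(O)c2)N1CCN1CCCCC1`, gives 60% in an ADME assay on Vero cells (Chlorocebus sabaeus) for cytotoxicity, read by neutral red uptake, tested at 787 ug/mL; a higher number here means a weaker effect of the compound at the concentration tested, a lower number a stronger effect.
Compound 2, `O=C1CSC(c2ccc(O)cc2)N1CCN1CCCCC1`, gives 57% in this assay.
Compound 3, `O=C1CSC(c2ccccc2[N+](=O)[O-])N1CCN1CCCCC1`, gives 100% in this assay.

Compound 3 stands highest of the three numbers in this assay, that is, it shows the weakest effect at the concentration tested; its number lies beyond the scatter above both compound 1 and compound 2, so it is the least active of the measured set. For the measured compounds named here, the only step between measured compounds that differ in one place is a number 3 percentage points lower from compound 1 to compound 2 (within the scatter), which changes a hydroxyl position on the phenyl ring and does not touch the group changed here.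

Compound 4, `O=C1CSC(c2ccccc2Cl)N1CCN1CCCCC1`, differs from compound 3 in one place: chloro in place of nitro on an aromatic carbon. Going by the values given here, no measured step bears on a chloro replacing a nitro, so the expectation rests on compound 3 alone, which gives 100%. Because compound 3 sits at the top of the scale with 100%, a move downward is the only direction open, and a modest one is expected. Compound 4 is estimated to give 85% in this assay, between 60% and 100%, an expected step of a number 15 percentage points lower from compound 3 to compound 4 (beyond the scatter).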

Compound 4, a percentage reported as activity, at one concentration (the size of the read-out at that concentration, not a potency): 38%
Compound 4: middle estimate off by 47 percentage points, on the high side; measured number outside the range, below it.
By their numbers in this assay, from the lowest: compound 4; then compounds 2 and 1 (each within the scatter of the next); then compound 3.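

In this assay the aromatic carbon ortho to a large group proves sensitive to what it carries: chloro in place of nitro there gives a number 62 percentage points lower from compound 3 to compound 4 (beyond the scatter), a large step that takes the series from its highest number to its lowest. The earlier compounds had shown only that moving the hydroxyl on the phenyl ring left the number within the scatter, whereas the 2-chlorophenyl group also separates compound 4 from both hydroxyphenyl compounds, with a number 19 percentage points lower from compound 2 to compound 4 (beyond the scatter) and a number 22 percentage points lower from compound 1 to compound 4 (beyond the scatter), both modest, so that the two ortho-substituted compounds lie on opposite sides of that pair. No measurement at hand accounts for the size or the direction of these steps.

Whether the low number belongs to chloro as such or to chloro at this place on the ring remains open, since the compounds shown offer no comparison with chloro on another aromatic carbon. As far as these compounds go, it also remains open where an amine, a methoxy group or a fluoro group on the same carbon would fall between the nitro and chloro compounds.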